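Series notes: halophenyl thioether variants, compound 3 pending

The compounds below may be only part of what the source reports. "The series", "measured", "known", "first", "only" and "open" are said of these compounds alone.

Measured so far:
Compound 1, `C#CCNC1CCc2c(SCCc3ccc(Br)cc3)cccc21`: in an ADME assay on isolated protein for inhibition of Amine oxidase [flavin-containing] B (Homo sapiens) (a lower number here means a stronger inhibitor, a higher number a weaker inhibitor), compound 1 gives 1250 nM.
Compound 2, `C#CCNC1CCc2c(SCCc3ccc(Cl)cc3)cccc21`: in this assay compound 2 gives 920 nM.

For the measured compounds named here, of the two numbers in hand, the one from compound 2 is the lower. The step of a 1.4-fold lower number from compound 1 to compound 2 (0.13 log units; within the scatter) is within the scatter, so the two compounds are not separated by this assay. The only structural difference measured so far is chloro in place of bromo on an aromatic carbon.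

Next is compound 3, `C#CCNC1CCc2c(SCCc3cccc(Br)c3)cccc21`. Relative to compound 2 the change is 3-bromophenyl in place of 4-chlorophenyl on a saturated chain carbon, two bonds along the chain from a sulfur. This both brings bromine back and moves the halogen to a different ring carbon. Going by the values given here, no measured step bears on the placement of the halogen; the one step that exists concerns the identity of the halogen at one and the same place, and it was within the scatter. On that basis the expected step is a 1.1-fold higher number from compound 2 to compound 3 (0.04 log units; within the scatter), with no reason from the data to expect a move beyond the scatter in either direction. For compound 3 the estimated value in this assay is 1000 nM, with a range from 400 nM to 2500 nM.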

Compound 3, half-maximal inhibitory concentration: 620 nM
Beside the measured number, compound 3's estimate is 1.6-fold (0.21 log units) above it; the measured number falls inside the stated range.
By their numbers in this assay, from the lowest: compounds 3, 2 and 1 (each within the scatter of the next).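

For the compounds shown here, the step of a 2.0-fold lower number from compound 1 to compound 3 (0.30 log units; within the scatter) is the first reading on 3-bromophenyl against 4-bromophenyl on a saturated chain carbon, two bonds along the chain from a sulfur, with the halogen itself held constant. It stays within the scatter, so this assay does not separate these two isomers, and the halogen's placement has so far produced no step beyond the scatter. The step of a 1.5-fold lower number from compound 2 to compound 3 (0.17 log units; within the scatter) changes the halogen and its placement together and is also within the scatter, so compounds 1, 2 and 3 form one unresolved group in which the separate contributions of the two changes cannot be read, and nothing at hand offers an explanation for these values.

Still open, on these data alone, is whether 3-chlorophenyl, which would complete the pairing of the two halogens with the two placements, would read any differently from its three relatives. Also open, as far as these compounds go, is whether unsubstituted phenyl, a phenyl bearing a carboxylic acid or an amine, or a longer chain in place of the present one would give a step beyond the scatter.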